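The source may report more compounds than this note shows. Statements on the series, on what has been measured and on what is new or still open speak of the compounds shown alone.

Compound 1 `OCc1cn(Cc2ccccc2)c2ccccc12` sits at the top of the three numbers measured in a functional assay on NCI-H460 cells (Homo sapiens) for cytotoxicity, read by sulforhodamine B assay, with a stated time of 3 days (on this read-out lower numbers stand for stronger inhibition and higher numbers for weaker inhibition), where compound 1 gives 112 nM. Compound 2 `OCc1cn(Cc2ccc(Cl)cc2)c2ccccc12` gives 16 nM in this assay, and compound 3 `OCc1cn(Cc2ccc(Br)cc2)c2ccccc12` gives 31 nM. Compound 4 `Cc1cccc(Cn2cc(CO)c3ccccc32)c1` differs from compound 1 by methyl in place of hydrogen on an aromatic carbon, the methyl sitting meta to a large group. Within the data shown here, the steps that bear on this both add a halogen on an aromatic carbon of the same ring: a 7.0-fold lower number from compound 1 to compound 2 (0.85 log units; beyond the scatter) and a 3.6-fold lower number from compound 1 to compound 3 (0.56 log units; beyond the scatter). Among the measured compounds shown here, neither step adds a methyl, so the new group has no direct precedent, and a smaller lowering than the halogen steps is expected, giving a 1.9-fold lower number from compound 1 to compound 4 (0.27 log units; within the scatter). Compound 4 is therefore estimated at 60 nM, within a range from 25 nM to 150 nM.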

Compound 4, half-maximal inhibitory concentration: 31 nM
Compound 4: the middle estimate sits 1.9-fold (0.29 log units) above what was measured; the measured number falls inside the stated range.
By their numbers in this assay, from the lowest: compounds 2, 3 and 4 (each within the scatter of the next); then compound 1.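

In this assay, methyl in place of hydrogen on this six-membered aromatic ring of carbon only also lowers the number (a 3.6-fold lower number from compound 1 to compound 4 (0.56 log units; beyond the scatter)), so a halogen is not required for a step beyond the scatter. Here the methyl sits meta to a large group, and this one added carbon is enough to produce that step. No measurement shown explains the change.

As far as these compounds go, whether a larger group such as ethyl or a longer chain would lower the number further at this place stays open. So does the outcome with an amine or a carboxylic acid there.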